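Swapping Chlorine for Fluorine on the Benzyl Ring

The source may hold more compounds than are shown below. What is called first, only, known or untested is meant among the compounds shown, and "the series" means these compounds.

Three measured compounds share one core and differ only in a single group on the benzyl ring. Compound 1 `Cc1ccc(-c2nc(N)c3cc(Cc4ccccc4)sc3n2)o1` carries no substituent there, and in a functional assay on CHO-K1 cells for antagonist activity at adenosine receptor A1 (Homo sapiens), read by a beta-galactosidase reporter and cAMP accumulation, with stated times of 15 min and 6 h (on this read-out higher numbers stand for weaker inhibition and lower numbers for stronger inhibition), compound 1 gives 298 nM. Compound 2 `COc1ccccc1Cc1cc2c(N)nc(-c3ccc(C)o3)nc2s1` carries a methoxy group, and in this assay compound 2 gives 122 nM. Compound 3 `Cc1ccc(-c2nc(N)c3cc(Cc4ccccc4Cl)sc3n2)o1` carries a chloro group, and in this assay compound 3 gives 26.1 nM, the lowest of the three numbers. The steps between them are a 2.4-fold lower number from compound 1 to compound 2 (0.39 log units; beyond the scatter), an 11-fold lower number from compound 1 to compound 3 (1.06 log units; beyond the scatter) and a 4.7-fold lower number from compound 2 to compound 3 (0.67 log units; beyond the scatter).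

Compound 4 `Cc1ccc(-c2nc(N)c3cc(Cc4ccccc4F)sc3n2)o1` has not yet been measured. It differs from compound 3 by fluoro in place of chloro on an aromatic carbon. Within the data shown here, no measured step tests this exact swap. Among the measured compounds shown here, the steps that bear on it are an 11-fold lower number from compound 1 to compound 3 (1.06 log units; beyond the scatter), which shows what the chloro group is worth against hydrogen, and a 4.7-fold lower number from compound 2 to compound 3 (0.67 log units; beyond the scatter), which shows that a different group at that position gives a higher number than chloro. Fluoro is another halogen, so part of the gain seen in compound 3 may be kept, but a somewhat higher number is expected for compound 4, as the expected step of a 3.1-fold higher number from compound 3 to compound 4 (0.49 log units; beyond the scatter) states. Compound 4 is therefore estimated at 80 nM, with a range from 30 nM to 200 nM.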

Compound 4, inhibition constant: < 16 nM
Compound 4 ended at the assay's limit; the forecaster's own chance of this, stated with the estimate: 2%; at least 5.0-fold (0.69 log units) between middle value and limit.
By their numbers in this assay, from the lowest: compound 3; then compound 2; then compound 1. At a limit, below all of these: compound 4.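

In this assay compound 4 gives no exact number, only a limit: the limit of < 16 nM in this assay, at which 1 of the 4 values shown sits. Even so, the result changes what chloro seemed to mean. The earlier compounds shown here left open whether the low number of compound 3 was special to chloro. The floor of the swap is an at least 1.6-fold lower number from compound 3 to compound 4 (0.21 log units; that floor lies within the scatter), so the two halogens cannot be placed in order, but chloro is clearly not needed for a low number at this place on the benzyl ring, ortho to a large group. The gains over the other two groups are firmer, with an at least 7.6-fold lower number from compound 2 to compound 4 (0.88 log units; beyond the scatter) and an at least 18-fold lower number from compound 1 to compound 4 (1.27 log units; beyond the scatter), so among these four compounds both halogens give lower numbers than hydrogen and methoxy, and none of the four goes against this.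

On these data alone, how far the true number of compound 4 lies past the limit stays open, and with it whether fluoro really beats chloro or merely matches it. Also open, as far as these compounds go, is whether the low numbers are tied to halogens at all, or whether a bromo group, a methyl group or an amine at this same place would give them too.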